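The compounds below may be only part of what the source reports. "The series", "measured", "known", "first", "only" and "open" are said of these compounds alone.

In a functional assay on HepG2 cells (Homo sapiens) for inhibition, read by MTT assay, with a stated time of 72 h (on this read-out higher numbers stand for weaker inhibition and lower numbers for stronger inhibition), compound 1 `Cc1ccc(NC(=O)C2CCN(C/C=C/c3ccccc3)CC2)cc1` gives 33900 nM and compound 2 `O=C(Nc1cccc(Cl)c1)C1CCN(C/C=C/c2ccccc2)CC1` gives 20000 nM while compound 3 `O=C(Nc1cccc(Br)c1)C1CCN(C/C=C/c2ccccc2)CC1` gives 19200 nM in the same range, so compound 3 stands within the scatter of both. The next entry is compound 4 `O=C(Nc1ccccn1)C1CCN(C/C=C/c2ccccc2)CC1`, which carries pyridin-2-yl in place of 3-bromophenyl on an amide-type nitrogen. Going by the values given here, three measured steps bear on this change: (a 1.7-fold lower number from compound 1 to compound 2 (0.23 log units; within the scatter)) and (a 1.8-fold lower number from compound 1 to compound 3 (0.25 log units; within the scatter)) on the amide-type nitrogen, and (a 1.0-fold lower number from compound 2 to compound 3 (0.02 log units; within the scatter)) on an aromatic carbon. All three are small and lie within the scatter. Among the compounds with values here, none of them brings in a ring with a hetero atom, so the series offers no direct precedent for this exchange. In this assay no step beyond the scatter is therefore expected, and the data support no direction. The estimated step is (a 1.1-fold higher number from compound 3 to compound 4 (0.06 log units; within the scatter)) and this is expected to stay within the scatter. For compound 4 the estimate is (22000 nM), with an expected range from 9000 nM to 55000 nM as the wider margin for the untested ring.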

Compound 4, half-maximal inhibitory concentration: 51100 nM
Beside the measured number, compound 4's estimate is 2.3-fold (0.37 log units) below it; the range from low to high includes it.
By their numbers in this assay, from the lowest: compounds 3, 2, 1 and 4 (each within the scatter of the next, the first and the last beyond it).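

In this assay the amide-type nitrogen now gives its first steps beyond the scatter: pyridin-2-yl in place of 3-bromophenyl (a 2.7-fold higher number from compound 3 to compound 4 (0.43 log units; beyond the scatter)) and in place of 3-chlorophenyl (a 2.6-fold higher number from compound 2 to compound 4 (0.41 log units; beyond the scatter)) both move towards weaker inhibition, modestly. In place of 4-methylphenyl the same ring stays within the scatter (a 1.5-fold higher number from compound 1 to compound 4 (0.18 log units; within the scatter)), so the change separates compound 4 from the two halogen-bearing compounds but not from compound 1. Nothing at hand accounts for these steps.

Open, on these data alone, is how an unsubstituted phenyl or a pyridin-3-yl group would read on this nitrogen, which would tell the ring nitrogen apart from the loss of the halogen. Also open, as far as these compounds go, is whether an amine or a carboxylic acid on this ring would shift the number beyond the scatter.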